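A few compounds are considered here, and "the series" means these few. Any claim that something is new, unique, unknown or untested is made for them only; others in the source may bear on it.

In an ADME assay on cells (Homo sapiens) for cytotoxicity, read by resazurin assay, with a stated time of 5 days (on this read-out lower numbers stand for higher toxicity in this test and higher numbers for lower toxicity in this test), three related compounds have been measured so far. Compound 1 `COc1ccc(-c2nc(CNc3cccc(Cl)c3)nc3ccsc23)cn1` gives > 50000 nM, which is a limit of the assay and not a number. Compound 3 `COc1ccc(-c2nc(CC(O)c3cccc(Cl)c3)nc3ccsc23)cn1` gives 31000 nM. Compound 2 `O=S(=O)(Cc1nc(-c2ccc(Cl)nc2)c2sccc2n1)c1cccc(Cl)c1` gives 70000 nM, the higher of the two actual numbers, and the gap to compound 3 lies beyond the usual scatter.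

Compound 4 `O=S(=O)(Cc1nc(-c2cccs2)c2sccc2n1)c1cccc(Cl)c1` has not yet been measured. Relative to compound 2, thiophen-2-yl takes the place of 6-chloropyridin-3-yl on an aromatic carbon (thiophen-2-yl in place of 6-chloropyridin-3-yl on an aromatic carbon). For the measured compounds named here, the only measured step, an at least 1.6-fold lower number from compound 1 to compound 3 (0.20 log units; that floor lies within the scatter), changes a different part of the molecule, so it says little about this swap. Going by the values given here, no measured pair tests this swap directly, so only a modest shift in this assay seems reasonable. The expected step, within the scatter, is a 1.4-fold lower number from compound 2 to compound 4 (0.15 log units; within the scatter). For compound 4 the estimated value is 50000 nM, with an expected range from 20000 nM to 100000 nM.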

Compound 4, half-maximal cytotoxic concentration: > 50000 nM
Compound 4: only a limit was reported; the forecaster's own chance of this, stated with the estimate: 35%; the middle value sits exactly at the limit.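

Compound 4 gives > 50000 nM, which is a limit and not a number, so the step from compound 2 to compound 4 cannot be read. The compounds shown leave open whether thiophen-2-yl in place of 6-chloropyridin-3-yl changes the number at all, and in which direction.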